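This account rests on a few compounds, and the source may have more. Where it says the series, first, only, none or still open, it means among the compounds named here.

Three compounds of a shared core have been run in an ADME assay on cells (Hepatocyte, Rattus norvegicus) for metabolic stability, using equilibrium dialysis; a lower number here means slower removal, a higher number faster removal of the compound. Compound 1, `CC(=O)N[C@@H]1CCC[C@H](C(=O)Nc2cc(-c3cnc(C)n3C(C)C)ccn2)C1`, gives 7.4 uL/min. Compound 2, `CC(=O)N[C@@H]1CCC[C@H](C(=O)Nc2cc(-c3cnn4c3CCCC4)c(F)cn2)C1`, gives 73 uL/min. Compound 3, `CC(=O)N[C@@H]1CCC[C@H](C(=O)Nc2cc(-c3cnc4n3CCCC4)c(Cl)cn2)C1`, gives 12 uL/min in this assay; it stands second highest of the three, within the scatter of compound 1, while compound 2 lies beyond the scatter above it. Compound 4, `CC(=O)N[C@@H]1CCC[C@H](C(=O)Nc2cc(-c3cnn4c3COCC4)c(Cl)cn2)C1`, is not yet measured. It differs from compound 3 in one place: a group of 9 heavy atoms (6 carbon, 2 nitrogen, 1 oxygen; one five-membered aromatic ring with 2 hetero atoms, one six-membered non-aromatic ring with 2 hetero atoms) in place of a group of 9 heavy atoms (7 carbon, 2 nitrogen; one five-membered aromatic ring with 2 hetero atoms, one six-membered non-aromatic ring with 1 hetero atom), on an aromatic carbon. Among the compounds with values here, no measured pair shows this change, so its size is open. A moderate upward step from compound 3 to compound 4 is expected, a 2.1-fold higher number from compound 3 to compound 4 (0.32 log units; beyond the scatter), because compound 2 with 73 uL/min shows how far the numbers in this series reach. The estimate for compound 4 in this assay is 25 uL/min, expected between 8 uL/min and 75 uL/min.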

Compound 4, intrinsic clearance in a liver preparation (reported as CLH), per the amount of preparation that the assay uses: 18 uL/min
Beside the measured number, compound 4's estimate is 1.4-fold (0.14 log units) above it; the range from low to high includes it.
By their numbers in this assay, from the lowest: compounds 1, 3 and 4 (each within the scatter of the next, the first and the last beyond it); then compound 2.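

In this assay, within the data shown here, this is the first pair of the series that differs in one place, and placing an oxygen in the six-membered non-aromatic ring of the group on the aromatic carbon, ortho to the chloro group and opposite the ring nitrogen, gives a 1.5-fold higher number from compound 3 to compound 4 (0.18 log units; within the scatter). At this position, then, the exchange, which adds a hydrogen-bond acceptor, leaves the two numbers indistinguishable. No measurement shown here accounts for this result. From the compounds shown here alone, it remains open how a methyl group or a nitrile in place of the chloro group would read with this oxygen-containing group. Going by these compounds, an amine on its non-aromatic ring is equally open.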